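The source may report more compounds than this note shows. Statements on the series, on what has been measured and on what is new or still open speak of the compounds shown alone.

In a physicochemical assay for solubility, read by HPLC, using the shake flask method, measured as kinetic solubility, with a stated time of 20 h, at pH 6.5, tested at 200 uM (on this read-out lower numbers stand for lower solubility and higher numbers for higher solubility), three sulfonamides on a shared core differ only in the group on the sulfonyl sulfur. Compound 1 `O=S(=O)(c1cccc(Nc2ccc3nccc(-c4ccncc4)c3n2)c1)N1CCCCC1`, with piperidin-1-yl, gives 15000 nM. Compound 2 `O=S(=O)(c1cccc(Nc2ccc3nccc(-c4ccncc4)c3n2)c1)N1CCCC1`, with pyrrolidin-1-yl, returns < 5000 nM, which is a limit of the assay and not a number. Compound 3 `O=S(=O)(NCCO)c1cccc(Nc2ccc3nccc(-c4ccncc4)c3n2)c1`, with (2-hydroxyethyl)amino, gives 115000 nM, the higher of the two actual numbers, and compound 1 is its nearest neighbour.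

Compound 4 `NCCNS(=O)(=O)c1cccc(Nc2ccc3nccc(-c4ccncc4)c3n2)c1` keeps this chain and alters its end: amino in place of hydroxy on a saturated chain carbon, two bonds along the chain from a sulfonamide nitrogen. This places amino in place of hydroxy on a saturated chain carbon, two bonds along the chain from a sulfonamide nitrogen. Among the compounds with values here, two measured steps bear on this site, the modest 7.7-fold higher number from compound 1 to compound 3 (0.88 log units; beyond the scatter) and the large at least 23-fold higher number from compound 2 to compound 3 (1.36 log units; beyond the scatter), the second resting on a limit. Within the data shown here, both replace a ring on the sulfur with the open chain, and neither exchanges hydroxy for amino, so the data hold no direct precedent for the new change. No step beyond the scatter is therefore expected in this assay, with only a slight lean upward. The expected change is a 1.2-fold higher number from compound 3 to compound 4 (0.09 log units; within the scatter). Compound 4 is estimated at 140000 nM, with an expected range from 70000 nM to 200000 nM.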

Compound 4, solubility: 200000 nM
Compound 4: middle estimate off by 1.4-fold (0.15 log units), on the low side; low and high end bracket the measured number.
By their numbers in this assay, from the lowest: compound 1; then compounds 3 and 4 (each within the scatter of the next). At a limit, below all of these: compound 2.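

In this assay, the exchange of hydroxy for amino on a saturated chain carbon, two bonds along the chain from a sulfonamide nitrogen, changes the end of the open chain rather than the group on the sulfonyl sulfur, and a 1.7-fold higher number from compound 3 to compound 4 (0.24 log units; within the scatter) shows that this exchange leaves the read-out within the scatter. The difference between the ring and the open chain seen earlier with compound 3 also holds with the (2-aminoethyl)amino chain, as a 13-fold higher number from compound 1 to compound 4 (1.12 log units; beyond the scatter) shows, so that difference does not depend on hydroxy being the end group in these compounds. The matching step from the pyrrolidin-1-yl ring, an at least 40-fold higher number from compound 2 to compound 4 (1.60 log units; beyond the scatter), is large but rests on a limit and not on a number: the limit of < 5000 nM in this assay, at which 1 of the 4 values shown sits.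

Going by these compounds, what a carboxylic acid, a dimethylamino group or a longer chain would do at this place remains open. The compounds shown also leave open whether amino and hydroxy would still read alike in this assay on a core other than the shared core, since all four compounds carry that one core.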